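This account rests on a few compounds, and the source may have more. Where it says the series, first, only, none or still open, it means among the compounds named here.

Among the compounds with values here, the three compounds measured so far share one core and differ at two points. Compound 1 `C/C(CCCC(=O)O)=N\OC(c1ccc(OCc2ccc3ccccc3n2)cc1)C1CCCCC1` gives 59 nM in a functional assay for inhibition of Polyunsaturated fatty acid 5-lipoxygenase (Homo sapiens); a lower number here means a stronger inhibitor, a higher number a weaker inhibitor. Compound 2 `O=C(O)/C=N/OC(c1ccc(OCc2ccc3ccccc3n2)cc1)C1CCCCCC1` gives 18 nM in this assay, and compound 3 `C/C(=N\OC(c1ccc(OCc2ccc3ccccc3n2)cc1)C1CCCCCC1)C(=O)O` gives 13 nM in this assay. Within the data shown here, compound 3 thus carries the lowest of the three numbers; its nearest neighbour is compound 2, and the only single-point step measured, a 1.4-fold lower number from compound 2 to compound 3 (0.14 log units; within the scatter), lies within the scatter. Compound 1 stands further off, with a number beyond the scatter from compound 3, but it differs from compound 3 in two places at once.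

Compound 4 `C/C(=N\OCc1ccc(OCc2ccc3ccccc3n2)cc1)C(=O)O` is not yet measured. It differs from compound 3 in one place: hydrogen in place of cycloheptyl on a saturated chain carbon bound to an aromatic carbon and an oxygen. Among the measured compounds shown here, no measured step touches that position, so the measured data offer no direct guide to the size or direction of this change. Since the group that leaves is large and every measured compound carries a ring at that carbon, the account expects the number for compound 4 to move upward, with wide uncertainty: a 9.2-fold higher number from compound 3 to compound 4 (0.97 log units; beyond the scatter). In this assay, compound 4 is therefore estimated at 120 nM, with a range from 20 nM to 700 nM.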

Compound 4, half-maximal inhibitory concentration: 1400 nM
Estimate against measurement, compound 4: 12-fold (1.07 log units) below, outside the stated range (above it).
By their numbers in this assay, from the lowest: compounds 3 and 2 (each within the scatter of the next); then compound 1; then compound 4.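

Within the data shown here, replacing cycloheptyl with hydrogen on the saturated chain carbon bound to an aromatic carbon and an oxygen gives, in this assay, a 110-fold higher number from compound 3 to compound 4 (2.03 log units; beyond the scatter) and is the first measured change at this position. Among these compounds, the earlier compounds all carried a ring at this carbon, so they could not show how much the number depends on that ring; the only earlier single-point step, a 1.4-fold lower number from compound 2 to compound 3 (0.14 log units; within the scatter), lies within the scatter, while this one is large and beyond it. Nothing measured here explains the size of this step.

The compounds shown do not tell how a methyl, an isopropyl or a phenyl group at this carbon would compare with hydrogen and cycloheptyl, so it remains open whether the number climbs gradually or abruptly as the group shrinks. Cyclohexyl also cannot be set against cycloheptyl, since compound 1, the only compound carrying cyclohexyl, differs from compound 3 in two places at once, and whether removing the ring would cost as much on the longer acid chain of compound 1 is likewise unresolved.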